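The source may report more compounds than this note shows. Statements on the series, on what has been measured and on what is new or still open speak of the compounds shown alone.

Measured so far in a functional assay on Jurkat cells for inhibition of nuclear factor NF-kappa-B complex (Homo sapiens); on this read-out higher numbers stand for weaker inhibition and lower numbers for stronger inhibition:
Compound 1, `CCOC(=O)c1cnc(C(C)(C)C)nc1NN1C(=O)C=C(C)C1=O`, gives 1000 nM.
Compound 2, `CCOC(=O)c1cnc(-c2cccs2)nc1NN1C(=O)C=C(C)C1=O`, gives 20 nM.
Compound 3, `CCOC(=O)c1cnc(Cc2ccccc2)nc1NN1C(=O)C=C(C)C1=O`, gives 7000 nM.

Compound 3 stands at the highest number of the three, which on this read-out means the weakest inhibition; the gaps are a 7.0-fold higher number from compound 1 to compound 3 (0.85 log units; beyond the scatter) and a 350-fold higher number from compound 2 to compound 3 (2.54 log units; beyond the scatter), both beyond the scatter. Compound 4, `CCOC(=O)c1cnc(Oc2ccccc2)nc1NN1C(=O)C=C(C)C1=O`, differs from compound 3 in one place: phenoxy in place of benzyl on an aromatic carbon. Among the compounds with values here, no measured step involves a phenoxy group, so the only guidance comes from the two steps that end at compound 3. Both show that leaving benzyl for another group lowered the number, by a modest amount with tert-butyl and by a large amount with thiophen-2-yl, itself an aromatic ring. Phenoxy keeps an aromatic ring but links it through an oxygen, which none of the measured compounds has. The step from compound 3 is therefore expected to lower the number, probably by a modest amount and with wide uncertainty: a 3.5-fold lower number from compound 3 to compound 4 (0.54 log units; beyond the scatter). Compound 4 is estimated at 2000 nM, within a range from 300 nM to 15000 nM.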

Compound 4, half-maximal inhibitory concentration: 15000 nM
Compound 4: the middle estimate sits 7.5-fold (0.88 log units) below what was measured; measured number inside the range.
By their numbers in this assay, from the lowest: compound 2; then compound 1; then compound 3; then compound 4.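

In this assay, replacing the carbon link of benzyl with the oxygen link of phenoxy did not bring stronger inhibition: the change gives a 2.1-fold higher number from compound 3 to compound 4 (0.33 log units; beyond the scatter), so neither of these two linked rings approaches the directly attached thiophen-2-yl. Against that group the change gives a 750-fold higher number from compound 2 to compound 4 (2.88 log units; beyond the scatter), and against the ring-free tert-butyl it gives a 15-fold higher number from compound 1 to compound 4 (1.18 log units; beyond the scatter), making compound 4 the weakest inhibitor of the four and showing that an aromatic ring at this position does not by itself give strong inhibition. Nothing available explains these differences.

From the compounds shown here alone, it remains open whether the low number of compound 2 depends on the thiophen-2-yl ring itself or on having a ring attached directly, which a plain phenyl group at this position would help to separate. Going by these compounds, how a phenylamino group, with a nitrogen link, would compare with benzyl and phenoxy also remains open.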